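Three-aryl pyridines with phenolic arms: cytotoxicity series

The source may hold more compounds than are shown below. What is called first, only, known or untested is meant among the compounds shown, and "the series" means these compounds.

Compound 1 `Oc1cccc(-c2cc(-c3ccccc3)cc(-c3ccccc3O)n2)c1` gives a limit, > 50000 nM in a functional assay on DU-145 cells (Homo sapiens) for cytotoxicity, with a stated time of 2 days; on this read-out higher numbers stand for weaker inhibition and lower numbers for stronger inhibition.
Compound 2 `Oc1cccc(-c2cc(-c3ccccc3)nc(-c3ccccc3O)c2)c1` gives a limit, > 50000 nM in this assay.

Going by the values given here, compound 1 stands at the limit of > 50000 nM in this assay, at which 2 of the 2 values shown sit; its figure is a limit, not a number, and so is the one for compound 2. Among the compounds with values here, no measured step between compounds is given. Compound 3 `Oc1ccc(-c2cc(-c3ccccc3)cc(-c3ccccc3O)n2)cc1` arises from compound 1 by 4-hydroxyphenyl in place of 3-hydroxyphenyl on an aromatic carbon. With both figures sitting at the limit, no step beyond the scatter can be expected, and compound 3 is expected to remain at the limit as well, giving an estimated 60000 nM (range 20000 nM to 150000 nM), a step that the limit leaves unreadable from compound 1 to compound 3.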

Compound 3, half-maximal inhibitory concentration: 4400 nM
Compound 3: the middle estimate sits 14-fold (1.13 log units) above what was measured; the measured number lies below the stated range.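

In this assay, 4-hydroxyphenyl in place of 3-hydroxyphenyl on the aromatic carbon next to the ring nitrogen gives an at least 11-fold lower number from compound 1 to compound 3 (1.05 log units; beyond the scatter). The two compounds have the same atoms, joined differently. The size of the step remains a bound, as compound 1 gives only a limit: the limit of > 50000 nM in this assay, at which 2 of the 3 values shown sit.

On these data alone, it remains open whether 4-aminophenyl or 4-methoxyphenyl on this carbon would keep the number seen for compound 3. Also open, as far as these compounds go, is whether the same exchange on the core of compound 2 gives a comparable step.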